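The source may report more compounds than this note shows. Statements on the series, on what has been measured and on what is new or still open speak of the compounds shown alone.

Measured so far:
- Compound 1 `CCOC(=O)C1=C(N/N=C(\c2ccc([N+](=O)[O-])cc2)N2CCN(c3ccc(F)cc3)CC2)Nc2[nH]nc(C)c2C1c1ccc(N(C)C)cc1`: > 100000 nM
- Compound 2 `CCOC(=O)C1=C(N/N=C(/C#N)C(=O)OCC)Nc2[nH]nc(C)c2C1c1ccc(N(C)C)cc1`: 35600 nM

Both compounds were tested in a functional assay on MCF7 cells (Homo sapiens) for inhibition, read by MTT assay, with a stated time of 48 h; on this read-out lower numbers stand for stronger inhibition and higher numbers for weaker inhibition. For compound 1, the entry of > 100000 nM is a limit of the assay and not a number. Among the measured compounds shown here, compound 2, at 35600 nM, therefore holds the only actual number available, and it is the reference point for what follows.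

Compound 3 `CCOC(=O)C1=C(N/N=C(\C#N)C(N)=O)Nc2[nH]nc(C)c2C1c1ccc(N(C)C)cc1` keeps the rest of compound 2 and differs in one place, on an amine nitrogen: a group of 7 heavy atoms (3 carbon, 3 nitrogen, 1 oxygen; no ring) in place of a group of 9 heavy atoms (5 carbon, 2 nitrogen, 2 oxygen; no ring), on an amine nitrogen. For the measured compounds named here, no measured step between compounds shows what a change of this kind does. In this assay, no shift beyond the scatter is therefore expected in either direction, although the uncertainty is wide. With compound 2 at 35600 nM as the anchor, the expected change is a 1.1-fold higher number from compound 2 to compound 3 (0.03 log units; within the scatter). Compound 3 is estimated at 38000 nM, with an expected range of 13000 nM to 100000 nM.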

Compound 3, half-maximal inhibitory concentration: 50100 nM
Estimate against measurement, compound 3: 1.3-fold (0.12 log units) below, within the range that was stated.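

Among the compounds shown here, at the amine nitrogen whose other neighbours are the double-bonded ring carbon, replacing the group of 9 heavy atoms with the group of 7 heavy atoms gives the first measured step at this place in this assay: a 1.4-fold higher number from compound 2 to compound 3 (0.15 log units; within the scatter). This step lies within the scatter, so the two groups are not told apart on this read-out, even though the entering group has 1 hydrogen-bond donor and the leaving group has 0. The series also reaches a ceiling in this assay: the limit of > 100000 nM in this assay, at which 1 of the 3 values shown sits.

From the compounds shown here alone, with a single step at this place, it remains open whether any other group there would move the number beyond the scatter. A carboxylic acid or a longer chain in the same place could test this, as could a change elsewhere on the shared core.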